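The source may report more compounds than this note shows. Statements on the series, on what has been measured and on what is new or still open speak of the compounds shown alone.

Two compounds of this series have numbers in a functional assay on HCT-116 cells (Homo sapiens) for inhibition, read by luminescence and resazurin assay, with a stated time of 3 days; on this read-out higher numbers stand for weaker inhibition and lower numbers for stronger inhibition. Compound 2 `CCNc1nc(NCc2ccc(C(=O)Nc3ccc(F)cc3)cc2)c2ccccc2n1` gives 1900 nM in this assay, the lowest of the two. Compound 1 `O=S(=O)(Nc1ccc(CNc2nc(NC3CC3)nc3ccccc23)cc1)c1ccc(F)cc1` gives 4900 nM in this assay; the two structures differ in more than one place, so only the two values stand side by side. Compound 3 `O=C(Nc1ccc(F)cc1)c1ccc(CNc2nc(NC3CC3)nc3ccccc23)cc1` differs from compound 2 in a single place: cyclopropyl in place of ethyl on a nitrogen on an aromatic ring. Among the measured compounds shown here, no single-change step in the data sizes this exchange. The step is expected to stay within the scatter, with no clear direction: a 1.1-fold lower number from compound 2 to compound 3 (0.02 log units; within the scatter). Compound 3 is estimated at 1800 nM in this assay, with a range from 600 nM to 5500 nM.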

Compound 3, half-maximal inhibitory concentration: 2700 nM
Compound 3: the middle estimate sits 1.5-fold (0.18 log units) below what was measured, and the stated range covers the measured number.
By their numbers in this assay, from the lowest: compounds 2, 3 and 1 (each within the scatter of the next, the first and the last beyond it).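

In this assay, cyclopropyl in place of ethyl on a nitrogen on an aromatic ring gives a 1.4-fold higher number from compound 2 to compound 3 (0.15 log units; within the scatter) and so leaves the number unresolved at this position. The other exchange, (4-fluorophenyl)carbamoyl in place of ((4-fluorophenyl)sulfonyl)amino on an aromatic carbon, gives a 1.8-fold lower number from compound 1 to compound 3 (0.26 log units; within the scatter) and likewise stays within the scatter. Nothing available bears on the reason for either result.

As far as these compounds go, whether a longer chain such as butyl or a 2-hydroxyethyl group on that nitrogen would move the number beyond the scatter stays open.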